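The source may hold more compounds than are shown below. What is called first, only, known or untested is meant among the compounds shown, and "the series" means these compounds.

The three measured compounds share one core and differ only at the ring fused to the sulfonamide nitrogen. In a functional assay on MDA-MB-231 cells (Homo sapiens) for antiproliferative activity, read by fluorescence and SYBR Green assay, with a stated time of 24 h (on this read-out higher numbers stand for weaker inhibition and lower numbers for stronger inhibition), compound 1 `CN1CCN(S(=O)(=O)c2ccc(N3CCCC3=O)cc2)c2ccccc21` gives 13 nM, compound 3 `COc1ccc2c(c1)N(C)CCN2S(=O)(=O)c1ccc(N2CCCC2=O)cc1` gives 14 nM, and compound 2 `Cc1ccc2c(c1)CCCN2S(=O)(=O)c1ccc(N2CCCC2=O)cc1` gives 17 nM; all three values sit within the scatter of one another, so compound 2 stands level with the rest. Among the measured compounds shown here, the only single-point step measured, a 1.1-fold higher number from compound 1 to compound 3 (0.03 log units; within the scatter), added a methoxy group without effect beyond the scatter. Compound 4 `CC(C)(C)c1ccc2c(c1)CCCN2S(=O)(=O)c1ccc(N2CCCC2=O)cc1` differs from compound 2 by tert-butyl in place of methyl on an aromatic carbon. For the measured compounds named here, no measured step touches this exchange, so the account can lean only on the flat picture so far. Compound 4 is therefore expected to give 20 nM, between 8 nM and 50 nM, the step of a 1.2-fold higher number from compound 2 to compound 4 (0.07 log units; within the scatter) being estimated to fall within the scatter.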

Compound 4, half-maximal inhibitory concentration: 608 nM
The estimate for compound 4 lay 30-fold (1.48 log units) below the measured number; the whole stated range lies below it.
By their numbers in this assay, from the lowest: compounds 1, 3 and 2 (each within the scatter of the next); then compound 4.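

In this assay, tert-butyl in place of methyl on this aromatic carbon gives a 36-fold higher number from compound 2 to compound 4 (1.55 log units; beyond the scatter), the first step shown to lie beyond the scatter. The number therefore depends strongly on the group at this position, which the earlier, closely grouped values did not reveal. Nothing available here bears on the reason for this step. On these data alone, whether an ethyl or isopropyl group in this place stays level with compound 2 or moves towards compound 4 remains open, as does the outcome with an amine or a carboxylic acid here.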